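Replacing Isopropyl on Oxygen: A Cytotoxicity Estimate

A few compounds are considered here, and "the series" means these few. Any claim that something is new, unique, unknown or untested is made for them only; others in the source may bear on it.

Compound 1 `C=CCO/N=C(\C#N)C(=O)NCC1=NOC(c2ccccc2)(c2ccccc2)C1` gives 100 ug/mL
Compound 2 `CC(C)O/N=C(\C#N)C(=O)NCC1=NOC(C(C)(C)C)C1` gives > 100 ug/mL

In a functional assay on MDBK cells (Bos taurus) for cytotoxicity (a higher number here means that more compound is tolerated, a lower number that less compound is tolerated), compound 2 gives > 100 ug/mL as a limit of the assay and not a number. Compound 3 `CC(C)(C)C1CC(CNC(=O)/C(C#N)=N/OCc2cccnc2)=NO1` differs from it by (pyridin-3-yl)methyl in place of isopropyl on an oxygen. Among the measured compounds shown here, the data hold no measured pair with this change. Compound 2 differs from compound 1 in more than one place, and compound 1 gives 100 ug/mL in this assay, so no large drop is expected. The expected a number no higher from compound 2 to compound 3 (the limit leaves the size open) is small, leaning toward less compound tolerated and probably within the scatter. For compound 3 the estimated value is 100 ug/mL, with an expected range from 50 ug/mL to 200 ug/mL.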

Compound 3, half-maximal cytotoxic concentration: > 100 ug/mL
Compound 3 was reported as a limit; the forecaster's own chance of this, stated with the estimate: 70%; the middle value sits exactly at the limit.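

Compound 2 and compound 3 both sit at a limit, so no step can be read between them, because neither gives an actual number: the limit of > 100 ug/mL in this assay, at which 2 of the 3 values shown sit.

The compounds shown leave open whether (pyridin-3-yl)methyl in place of isopropyl on an oxygen changes how much compound the cells tolerate.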